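This account rests on a few compounds, and the source may have more. Where it says the series, first, only, none or still open, it means among the compounds named here.

Among the compounds with values here, in a functional assay on HepG2 cells (Homo sapiens) for cytotoxicity, read by MTT assay, with a stated time of 24 h (on this read-out higher numbers stand for weaker inhibition and lower numbers for stronger inhibition), compound 1 `Cc1ccc(S(=O)(=O)N2C/C(=C\c3cccnc3)C(=O)/C(=C/c3ccccc3C(F)(F)F)C2)cc1` gives 2930 nM and compound 2 `O=C1/C(=C/c2cccnc2)CN(S(=O)(=O)c2ccc(Br)cc2)C/C1=C\c1ccccc1C(F)(F)F` gives 2730 nM, so compound 2 stands level with the only other measured compound. Compound 3 `N#Cc1ccc(S(=O)(=O)N2C/C(=C\c3cccnc3)C(=O)/C(=C/c3ccccc3C(F)(F)F)C2)cc1` keeps the shared core and changes one substituent, with cyano in place of bromo on an aromatic carbon, para to a large group: cyano in place of bromo on an aromatic carbon.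

Within the data shown here, only one measured step bears on this position: a 1.1-fold lower number from compound 1 to compound 2 (0.03 log units; within the scatter). That step, bromo in place of methyl, stayed within the scatter. Among the measured compounds shown here, it is a single step, and no nitrile-bearing compound has been measured yet, so the evidence is thin. No step beyond the scatter is therefore expected in this assay, and no direction is favoured. The expected step is a 1.0-fold lower number from compound 2 to compound 3 (0.00 log units; within the scatter). Compound 3 is estimated at 2700 nM, with an expected range of 1400 nM to 5000 nM.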

Compound 3, half-maximal inhibitory concentration: 5060 nM
Compound 3: the middle estimate sits 1.9-fold (0.27 log units) below what was measured; the whole stated range lies below it.
By their numbers in this assay, from the lowest: compounds 2, 1 and 3 (each within the scatter of the next).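

With the nitrile, this position has now carried methyl, bromo and cyano, and in this assay each new step stays within the scatter: a 1.9-fold higher number from compound 2 to compound 3 (0.27 log units; within the scatter) and a 1.7-fold higher number from compound 1 to compound 3 (0.24 log units; within the scatter). Replacing 4-bromophenyl with 4-cyanophenyl adds a triple bond and a hydrogen-bond acceptor to this position, yet compound 3 remains level with compound 1 and compound 2 on this read-out. Nothing available accounts for the size of these steps.

From the compounds shown here alone, whether an amine or a carboxylic acid at this same place would give a step beyond the scatter remains open. Going by these compounds, it is also open whether these three groups would stay level if the trifluoromethyl group elsewhere on the shared core were replaced by a longer chain.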